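Trimming the chain on a cyanoguanidine core

The source may report more compounds than this note shows. Statements on the series, on what has been measured and on what is new or still open speak of the compounds shown alone.

Measured so far:
compound 1 `CCCCC/N=C(\NC#N)Nc1cccnc1` — 20 mg/kg
compound 2 `CC(C)CC/N=C(\NC#N)Nc1cccnc1` — 20 mg/kg
compound 3 `CCC(C)C(C)/N=C(\NC#N)Nc1ccncc1` — 8 mg/kg

All three were tested in a functional assay on the whole organism (blood, strain Wistar-Okamoto) with Rattus norvegicus as the target, with a stated time of 5 days; on this read-out higher numbers stand for an effect only at larger amounts of compound and lower numbers for an effect already at smaller amounts. Compound 3 gives the lowest number of the three: compound 1 sits at a number beyond the scatter above it, and compound 2 does the same. Among the compounds with values here, the one step between compounds that differ in a single place is no change at the digits printed from compound 1 to compound 2 (within the scatter), which shows that adding a branch to the chain left the number unchanged within the scatter.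

Compound 4 `CCC(C)(C)/N=C(\NC#N)Nc1ccncc1` has not been measured. Compared with compound 3 the change is 1,1-dimethylpropyl in place of 1,2-dimethylbutyl on a double-bonded nitrogen. Within the data shown here, no measured step covers this exact change; the closest guide is the step from compound 1 to compound 2, where reshaping the chain did nothing beyond the scatter. The expected step of a 1.3-fold higher number from compound 3 to compound 4 (0.10 log units; within the scatter) from compound 3 to compound 4 is therefore small, with a slight lean towards a higher number since one carbon is lost. Compound 4 is estimated at 10 mg/kg, expected between 4 mg/kg and 25 mg/kg.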

Compound 4, minimum effective dose: 2.5 mg/kg
Compound 4: middle estimate off by 4.0-fold (0.60 log units), on the high side; measured number outside the range, below it.
By their numbers in this assay, from the lowest: compound 4; then compound 3; then compounds 1 and 2 (each within the scatter of the next).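

Moving from 1,2-dimethylbutyl to 1,1-dimethylpropyl on the double-bonded nitrogen gives a 3.2-fold lower number from compound 3 to compound 4 (0.51 log units; beyond the scatter) in this assay, so the chain at this position can shift the number beyond the scatter. The earlier reshaping of a chain, no change at the digits printed from compound 1 to compound 2 (within the scatter), did not show this, and the new step also shows that a chain with fewer carbons can give the lower number. The change alters chain length and branching together, and nothing here shows which of the two matters or explains the drop.

On these data alone, it remains open whether a smaller tert-butyl group or a ring such as cyclohexyl on this nitrogen would lower the number further. Also open, as far as these compounds go, is whether 1,1-dimethylpropyl would give a similar step on the core of compound 1.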